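Swapping a sulfonamide for an amide on the shared chain

A few compounds are considered here, and "the series" means these few. Any claim that something is new, unique, unknown or untested is made for them only; others in the source may bear on it.

Compound 2 `O=S(=O)(NCCNc1nccc(-c2c(-c3cccc(F)c3)nc3sccn23)n1)c1ccc(Br)cc1` carries a (4-bromophenyl)sulfonyl group on the amine nitrogen of a short chain. In a functional assay on A-375 cells (Homo sapiens) for cytotoxicity, read by MTT assay (a lower number here means a stronger inhibitor, a higher number a weaker inhibitor), compound 2 gives 13500 nM, the lowest of the two numbers recorded, with compound 1 `O=S(=O)(NCCCNc1nccc(-c2c(-c3cccc(F)c3)nc3sccn23)n1)c1cccc(F)c1` close by: in this assay compound 1 gives 13700 nM, and the step of a 1.0-fold lower number from compound 1 to compound 2 (0.01 log units; within the scatter) is within the scatter. Compound 3 `O=C(NCCNc1nccc(-c2c(-c3cccc(F)c3)nc3sccn23)n1)c1c(F)cccc1F` differs from compound 2 by (2,6-difluorophenyl)carbonyl in place of (4-bromophenyl)sulfonyl on an amine nitrogen. Among the compounds with values here, the only measured step, from compound 1 to compound 2, alters the aryl group on the sulfonyl and the chain length, not the sulfonyl itself, so it gives no direct guidance on replacing a sulfonyl with a carbonyl. Compound 3 is therefore expected to stay near compound 2, with a step of a 1.1-fold lower number from compound 2 to compound 3 (0.05 log units; within the scatter) that may fall either way. The estimate for compound 3 is 12000 nM, with a range from 4000 nM to 40000 nM.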

Compound 3, half-maximal inhibitory concentration: 2700 nM
Compound 3: the middle estimate sits 4.4-fold (0.65 log units) above what was measured; the measured number lies below the stated range.
By their numbers in this assay, from the lowest: compound 3; then compounds 2 and 1 (each within the scatter of the next).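

In this assay, the change on this amine nitrogen moves the number beyond the scatter, a step of a 5.0-fold lower number from compound 2 to compound 3 (0.70 log units; beyond the scatter), as (2,6-difluorophenyl)carbonyl enters and (4-bromophenyl)sulfonyl leaves. The wider change reads much the same, at a 5.1-fold lower number from compound 1 to compound 3 (0.71 log units; beyond the scatter), so the two sulfonyl compounds, within the scatter of each other, both give higher numbers than the carbonyl compound. Nothing in the data accounts for this difference.

The sulfonyl-to-carbonyl swap and the change of aryl group arrive together, so the compounds shown cannot separate their contributions; a (4-bromophenyl)carbonyl or a (2,6-difluorophenyl)sulfonyl group on the same chain would do so. Going by these compounds, whether the carbonyl series keeps its number on a longer chain also remains open.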